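This account rests on a few compounds, and the source may have more. Where it says the series, first, only, none or still open, it means among the compounds named here.

Of the compounds shown here, two built on a shared core have been tested in a functional assay on ME-180 cells (Homo sapiens) for cytotoxicity, read by MTT assay, with a stated time of 72 h; on this read-out higher numbers stand for weaker inhibition and lower numbers for stronger inhibition. Compound 1, `COc1ccc(C(=O)c2cc(OC)c(OC)c(OC)c2)cc1NC(=O)/C=C/c1ccc(F)cc1`, gives 300 nM in this assay. Compound 2, `COc1ccc(/C=C/C(=O)Nc2cc(C(=O)c3cc(OC)c(OC)c(OC)c3)cc(OC)c2OC)cc1OC`, gives 6700 nM in this assay, the highest of the two numbers; its nearest neighbour is compound 1, whose number is lower by a margin beyond the usual scatter. Compound 3, `COc1cc(C(=O)c2cc(OC)c(OC)c(OC)c2)cc(NC(=O)/C=C/c2cc(F)c(F)c(F)c2)c1OC`, has not yet been measured. It differs from compound 2 in one place: 3,4,5-trifluorophenyl in place of 3,4-dimethoxyphenyl on a double-bonded chain carbon bound to a double-bonded chain carbon. Among the measured compounds shown here, no pair of measured compounds differs only at this spot, so the size of the step cannot be read off directly. Compound 1 carries a fluorine-bearing phenyl on its double-bonded chain and gives 300 nM, but its core also differs from that of compound 2, so this is only a loose guide. A move toward a lower number, beyond the scatter, is expected, amounting to a 4.5-fold lower number from compound 2 to compound 3 (0.65 log units; beyond the scatter). Compound 3 is estimated at 1500 nM, with a likely range from 300 nM to 7000 nM.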

Compound 3, half-maximal inhibitory concentration: 7100 nM
For compound 3 the middle estimate is 4.7-fold (0.68 log units) below the measured one, outside the stated range (above it).
By their numbers in this assay, from the lowest: compound 1; then compounds 2 and 3 (each within the scatter of the next).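

Across this assay, placing 3,4,5-trifluorophenyl where 3,4-dimethoxyphenyl stood on a double-bonded chain carbon bound to a double-bonded chain carbon gives a 1.1-fold higher number from compound 2 to compound 3 (0.03 log units; within the scatter), so the two groups cannot be told apart on the core of compound 2. Among the compounds shown here, this is the first direct reading at this spot, and it shows that a fluorine-bearing phenyl here is not enough by itself to give this core a lower number. For the compounds shown here, nothing measured so far explains why these two quite different groups give matching results.

Going by these compounds alone, the core of compound 1 has no matching pair at this spot, so it remains unknown whether the same swap would leave its number unmoved. Also open, on these data alone, is how the core of compound 2 would respond to an amine on this phenyl ring or to a longer chain at this spot.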